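The compounds below may be only part of what the source reports. "The series", "measured", "known", "first", "only" and "open" are said of these compounds alone.

Compound 1 `COc1ccc(C(=O)c2cc(OC)c(OC)c(OC)c2)cc1NC(=O)/C=C/c1ccc(F)cc1` and compound 2 `COc1cc(/C=C/C(=O)Nc2cc(C(=O)c3cc(OC)c(OC)c(OC)c3)ccc2OC)ccc1F` share one core and differ in a single place on the outer aromatic ring: hydrogen in place of methoxy on an aromatic carbon. In a functional assay on B16 cells (Mus musculus) for cytotoxicity, read by MTT assay, with a stated time of 72 h (on this read-out higher numbers stand for weaker inhibition and lower numbers for stronger inhibition), compound 2 gives 16300 nM, while compound 1 gives 400 nM, so that this change made a 41-fold lower number from compound 2 to compound 1 (1.61 log units; beyond the scatter). Compound 3 `COc1ccc(/C=C/C(=O)Nc2cc(C(=O)c3cc(OC)c(OC)c(OC)c3)cc(OC)c2OC)cc1OC` is built on a different core, and the difference between the two cores is not broken down here. In this assay compound 3 gives 1300 nM, a number that stands between the other two, beyond the scatter from each.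

Compound 4 `COc1ccc(/C=C/C(=O)Nc2cc(C(=O)c3cc(OC)c(OC)c(OC)c3)cc(OC)c2OC)cc1` has not yet been measured. Within the data shown here, it arises from compound 3 by the same kind of change as the one from compound 2 to compound 1: hydrogen in place of methoxy on an aromatic carbon. The surroundings are not identical, though: in compound 2 the departing methoxy is ortho to a fluoro group, in compound 3 it is ortho to a methoxy group, and in both it is meta to a large group. Because a 41-fold lower number from compound 2 to compound 1 (1.61 log units; beyond the scatter) was large, a lower number for compound 4 is expected as well. The cores differ, the groups around the place differ, and the change occurs only twice among these compounds, so the earlier step is only a loose guide. The step from compound 3 to compound 4 in this assay is therefore expected to be smaller, namely a 3.7-fold lower number from compound 3 to compound 4 (0.57 log units; beyond the scatter). For compound 4 the estimate is 350 nM, with a likely range from 100 nM to 1300 nM.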

Compound 4, half-maximal inhibitory concentration: 9400 nM
The estimate for compound 4 lay 27-fold (1.43 log units) below the measured number; measured number above the stated range.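

In this assay, putting hydrogen in place of the methoxy group gave a 7.2-fold higher number from compound 3 to compound 4 (0.86 log units; beyond the scatter), so the change that lowered the number on the core of compound 2 raised it on the core of compound 3. The two steps differ in direction and clearly in size, which shows that the effect of this change did not carry over from one core to the other in this series: the same change on two cores in this assay, a 41-fold lower number (1.61 log units; beyond the scatter) from compound 2 to compound 1 and a 7.2-fold higher number (0.86 log units; beyond the scatter) from compound 3 to compound 4, 290-fold (2.47 log units) apart, beyond the scatter of two such steps

What this does not show is the reason for the reversal, since the cores differ and so do the groups around the changed place, and two steps cannot separate these factors or show which core's behaviour is more typical of the series.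

The compounds shown leave open what other groups would do at this place on either core, such as a hydroxyl group, an amine or a longer ethoxy chain in place of the methoxy. They also leave open whether the change would follow the first step, the second or neither on a further core, so a third pair of compounds differing only in this methoxy group would be needed to test that.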